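The compounds below may be only part of what the source reports. "The series", "measured", "known", "first", "only" and "open" are said of these compounds alone.

Of the compounds shown here, three have so far been measured in a functional assay on PC-9 cells (Homo sapiens) for inhibition, read by MTT assay, with a stated time of 72 h; a lower number here means a stronger inhibitor, a higher number a weaker inhibitor. Compound 1, `CCCCCc1c(C)nc2nc(SCc3ccc(Cl)cc3)nn2c1Nc1cc(-c2ccccc2)[nH]n1`, gives only a limit in this assay, > 50000 nM. Compound 3, `COc1ccc(Cn2ccc(Nc3cc(C)nc4nc(SCc5ccc(Br)cc5)nn34)n2)cc1`, likewise reaches only a limit, > 50000 nM. Among the compounds with values here, compound 2, `Cc1cc(Nc2cc(-c3ccccc3)[nH]n2)n2nc(SCc3ccc(F)cc3)nc2n1`, is the single compound with a number in this assay, where it gives 8110 nM; it therefore stands alone as the only measured value, the other two sitting at the limit of > 50000 nM in this assay, at which 2 of the 3 values shown sit. No two of these three compounds differ from each other in just one place, so no measured step can be read from them, and no pattern can be claimed beyond the bare values.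

Compound 4, `Cc1cc(Nc2cc(-c3ccccc3)[nH]n2)n2nc(SCC(=O)c3ccccc3)nc2n1`, has not yet been measured. It differs from compound 2 in one place: benzoyl in place of 4-fluorophenyl on a saturated chain carbon bound to a sulfur. Within the data shown here, nothing among the measured compounds shows how a benzoyl in place of a 4-fluorophenyl on a saturated chain carbon bound to a sulfur changes the result, so the expectation rests on compound 2 alone. The step expected here is a 1.6-fold higher number from compound 2 to compound 4 (0.20 log units; within the scatter), a small loss that could well fall within the scatter. Compound 4 is thus estimated to give 13000 nM in this assay, with a likely range from 3500 nM to 50000 nM.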

Compound 4, half-maximal inhibitory concentration: 4450 nM
Beside the measured number, compound 4's estimate is 2.9-fold (0.47 log units) above it; measured number inside the range.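

Within the data shown here, this is the first measured step in the set, and it concerns the group on a saturated chain carbon bound to a sulfur: in this assay, benzoyl in place of 4-fluorophenyl gives a 1.8-fold lower number from compound 2 to compound 4 (0.26 log units; within the scatter). The exchange removes a fluorine and brings in an oxygen, a double bond outside the aromatic ring and a hydrogen-bond acceptor, yet the two results cannot be told apart from ordinary variation between repeated measurements. This position therefore accepts this particular exchange with no readable shift in the result, and compound 4, with its carbonyl, gives a number rather than a limit.

As far as these compounds go, it remains open whether another group at this position, such as a carboxylic acid, an amine or a longer chain, would shift the result beyond the scatter. Compound 1 and compound 3 each differ from the compounds with numbers in more than one place and give only a limit of the assay, so they say nothing about this position: the limit of > 50000 nM in this assay, at which 2 of the 4 values shown sit.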